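Chain extension from compound 1 to compound 4

This account rests on a few compounds, and the source may have more. Where it says the series, first, only, none or still open, it means among the compounds named here.

Compound 1 `CCCCCCCC#Cc1cc2cn(COCCO)c(=O)nc2o1` stands at > 50000 nM in a functional assay on HEL cells (Homo sapiens) (a higher number here means that more compound is tolerated, a lower number that less compound is tolerated), and this value is a limit, not a number.

Compound 2 `CCCCCCCc1cc2cn(COCCO)c(=O)nc2o1` gives 140000 nM in this assay.

Compound 3 `CCCCCCc1cc2cn(COCCO)c(=O)nc2o1` gives > 200000 nM, which is also a limit.

Compound 4 `CCCCCCCCCC#Cc1cc2cn(COCCO)c(=O)nc2o1` is not yet measured. It differs from compound 1 by ethyl in place of hydrogen on a saturated chain carbon, seven bonds along the chain from a triple-bonded carbon.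

For the measured compounds named here, only one measured step bears on this change, an at least 1.4-fold higher number from compound 2 to compound 3 (0.15 log units; that floor lies within the scatter), and its floor lies within the scatter. It fixes no firm size for a change in chain length. Going by the values given here, with that step as the only guide, no step beyond the scatter is expected in this assay for the added ethyl.

Compound 4 is expected at 60000 nM, with an estimated range of 20000 nM to 200000 nM.

The estimate corresponds to an expected step that the limit leaves unreadable from compound 1 to compound 4, reckoned against a limit rather than a number.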

Compound 4, half-maximal cytotoxic concentration: > 50000 nM
Compound 4 ended at the assay's limit; the forecaster's own chance of this, stated with the estimate: 55%; the middle value does not contradict the limit.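

In this assay compound 4 gives > 50000 nM as a limit. Compound 1 gives > 50000 nM as a limit too, so no step can be read between compound 1 and compound 4. The compounds shown leave open whether ethyl in place of hydrogen at this place changes the tolerated concentration at all.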